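The compounds below may be only part of what the source reports. "The series", "measured", "known", "first", "only" and "open" are said of these compounds alone.

Working notes on the series. Three compounds share one core and differ only in the group on the same aromatic carbon. Compound 1 `Nc1cc(N)c2nc(-c3ccccc3)c(Oc3ccc(Cl)c(Cl)c3)nc2c1` carries a 3,4-dichlorophenoxy there; in a functional assay on NCI-H460 cells (Homo sapiens) for inhibition, read by sulforhodamine B assay, with a stated time of 48 h (a higher number here means a weaker inhibitor of growth, a lower number a stronger inhibitor of growth), compound 1 gives 70800 nM. Compound 2 `Nc1cc(N)c2nc(-c3ccccc3)c(NCc3ccc(F)cc3)nc2c1` carries a (4-fluorobenzyl)amino and gives 25700 nM. Compound 3 `Nc1cc(N)c2nc(-c3ccccc3)c(Sc3ccc(Cl)c(Cl)c3)nc2c1` carries a (3,4-dichlorophenyl)sulfanyl and gives 33900 nM. Compound 3 thus stands second highest of the three numbers: its nearest neighbour is compound 2, a difference within the scatter, while compound 1 lies furthest from it, with a 2.1-fold lower number from compound 1 to compound 3 (0.32 log units; beyond the scatter). The other measured steps are a 2.8-fold lower number from compound 1 to compound 2 (0.44 log units; beyond the scatter) and a 1.3-fold higher number from compound 2 to compound 3 (0.12 log units; within the scatter).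

Compound 4 `Nc1cc(N)c2nc(-c3ccccc3)c(Sc3ccc(F)cc3)nc2c1` differs from compound 3 by 4-fluorophenyl in place of 3,4-dichlorophenyl on a sulfur, so the sulfur link is kept and only the aryl substituents change. Going by the values given here, no measured step isolates this exchange: the step from compound 1 to compound 2 changes both the linking atom and the aryl group at once, and the other two steps change the linking atom only. Among the measured steps the replacement of a linking atom gave the larger shifts, and the whole series spans a narrow window. A step from compound 3 to compound 4 of a 1.1-fold higher number from compound 3 to compound 4 (0.05 log units; within the scatter) is therefore expected in this assay, one that is not expected to go beyond the scatter in either direction. Compound 4 is estimated at 38000 nM, with a range of 14000 nM to 105000 nM.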

Compound 4, concentration for total growth inhibition: 66100 nM
For compound 4 the middle estimate is 1.7-fold (0.24 log units) below the measured one, within the range that was stated.
By their numbers in this assay, from the lowest: compounds 2, 3, 4 and 1 (each within the scatter of the next, the first and the last beyond it).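

In this assay the exchange of 3,4-dichlorophenyl for 4-fluorophenyl on a sulfur can now be read directly (a 1.9-fold higher number from compound 3 to compound 4 (0.29 log units; within the scatter)), and with the sulfur link kept, this change of aryl group stays within the scatter. Compound 4 also cannot be told apart from the 3,4-dichlorophenoxy compound (a 1.1-fold lower number from compound 1 to compound 4 (0.03 log units; within the scatter)), whereas the exchange of (4-fluorobenzyl)amino for (4-fluorophenyl)sulfanyl on the same aromatic carbon goes beyond the scatter (a 2.6-fold higher number from compound 2 to compound 4 (0.41 log units; beyond the scatter)), so compound 2 is now separated from compound 4 and compound 1 but not from compound 3. No measurement shown here gives a reason for any of these steps.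

As far as these compounds go, it remains open whether the gap between compound 2 and compound 4 belongs to the nitrogen or sulfur link or to the added methylene of the benzyl group, a question that a (4-fluorobenzyl)sulfanyl or a (4-fluorophenyl)amino group at this carbon would address. Also open, from the compounds shown here alone, is how a group of another kind, such as a morpholine or a carboxylic acid on the aryl group, would read in this assay at this position.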